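Compound 3 to compound 4: thiazole for pyridine

The compounds below may be only part of what the source reports. "The series", "measured", "known", "first", "only" and "open" are said of these compounds alone.

Values in an ADME assay on LLC-MK2 cells (Macaca mulatta) for cytotoxicity, read by spectrophotometry and crystal violet staining, with a stated time of 4 days; a higher number here means that more compound is tolerated, a lower number that less compound is tolerated:
- Compound 1 `CC(C)n1ncc2c(C(=O)Nc3cccc(C(N)=O)c3)cc(-c3cccs3)nc21`: 25000 nM
- Compound 2 `CC(C)n1ncc2c(C(=O)Nc3ccc(F)cc3)cc(-c3ccsc3)nc21`: > 200000 nM, a limit of the assay
- Compound 3 `CC(C)n1ncc2c(C(=O)Nc3ccccc3F)cc(-c3cccnc3)nc21`: 50000 nM

Compound 3 at 50000 nM and compound 1 at 25000 nM lie within the scatter of each other. For the measured compounds named here, these are the only two numbers so far. The entry for compound 2 is a limit and not a number.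

Compound 4 `CC(C)n1ncc2c(C(=O)Nc3ccccc3F)cc(-c3cncs3)nc21` carries 1,3-thiazol-5-yl in place of pyridin-3-yl on an aromatic carbon. Going by the values given here, no pair of measured compounds differs in one place only, so no measured step bears on this change. The expectation therefore rests on compound 3 at 50000 nM, and no shift beyond the scatter is expected in either direction in this assay. The estimated change is a 1.3-fold lower number from compound 3 to compound 4 (0.10 log units; within the scatter), which is expected to stay within the scatter.

For compound 4 the estimated value is 40000 nM, with an expected range of 15000 nM to 120000 nM.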

Compound 4, half-maximal cytotoxic concentration: 100000 nM
Beside the measured number, compound 4's estimate is 2.5-fold (0.40 log units) below it, within the range that was stated.
By their numbers in this assay, from the lowest: compounds 1, 3 and 4 (each within the scatter of the next, the first and the last beyond it). At a limit, above all of these: compound 2.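

In this assay, for the compounds shown here, the exchange of pyridin-3-yl for 1,3-thiazol-5-yl gives a 2.0-fold higher number from compound 3 to compound 4 (0.30 log units; within the scatter) and is the first step that changes one place only. At this position, next to the ring nitrogen, a six-membered aromatic ring can thus give way to a five-membered one carrying sulfur with no shift beyond the scatter, for this one pair. No measured property in these notes bears on a cause for the step.

From the compounds shown here alone, whether the exchange reads the same with another amide partner stays open, since compounds 1 and 2 differ from compounds 3 and 4 in more than one place. Also open, going by these compounds, is how this assay would respond to a morpholine or a carboxylic acid at this position.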